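The source may report more compounds than this note shows. Statements on the series, on what has been measured and on what is new or still open speak of the compounds shown alone.

Going by the values given here, compound 2, `CC1CCN(c2c(S(=O)(=O)c3cc(Cl)cc(Cl)c3)cnc3c(F)cccc23)CC1`, sits second highest of the three compounds so far characterised in an assay on isolated protein for displacement of a labelled ligand from metabotropic glutamate receptor 5 (Homo sapiens), with a stated time of 60 min, tested at 1 uM; a higher number here means more inhibition at the concentration tested (going by the name of the read-out), a lower number less inhibition. Its inhibition of 82% lies closest to compound 1, `CC1CCN(c2c(S(=O)(=O)c3ccc(Cl)cc3)cnc3cc(Cl)ccc23)CC1`, which gives 91%, a gap within the scatter, and furthest from compound 3, `COc1cccc(S(=O)(=O)c2cnc3ccc(OC)cc3c2N2CCC(C)CC2)c1`, which gives 0%, a gap beyond the scatter. Compound 4, `CC1CCN(c2c(S(=O)(=O)c3ccc(Cl)cc3)cnc3c(F)cccc23)CC1`, is not yet measured. It differs from compound 2 in one place: 4-chlorophenyl in place of 3,5-dichlorophenyl on a sulfonyl sulfur. Compound 1 already carries the 4-chlorophenyl on its sulfonyl sulfur, and its 91% does not separate from compound 2 beyond the scatter, so no step beyond the scatter is expected in this assay, perhaps a slight upward drift. Compound 4 is therefore estimated at 87%, expected between 72% and 97%, a step of a number 5 percentage points higher from compound 2 to compound 4 (within the scatter).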

Compound 4, a percentage reported as inhibition, at one concentration (the size of the read-out at that concentration, not a potency): 85%
Beside the measured number, compound 4's estimate is 2 percentage points above it; low and high end bracket the measured number.
By their numbers in this assay, from the lowest: compound 3; then compounds 2, 4 and 1 (each within the scatter of the next).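

In this assay, going by these compounds alone, replacing 3,5-dichlorophenyl with 4-chlorophenyl on the sulfonyl sulfur gives a number 3 percentage points higher from compound 2 to compound 4 (within the scatter), the first reading of this position with the rest of the molecule held constant. The assay does not separate these two chlorophenyl groups at this position, so a chlorine count of either two or one is compatible with high inhibition here. Nothing measured here explains this result.

On these data alone, it remains open how an unsubstituted phenyl, or a phenyl carrying an amine or a carboxylic acid, would read on the sulfonyl sulfur. Compound 3 differs from these compounds in more than one place, so no single feature can be tied to its value.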